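Alkyl and hydroxyalkyl variation on the ring nitrogen of the core

The source may hold more compounds than are shown below. What is called first, only, known or untested is meant among the compounds shown, and "the series" means these compounds.

Measured so far in an assay on isolated protein (Oryctolagus cuniculus) with Thromboxane-A synthase (Homo sapiens) as the target, tested at 1 uM; a lower number here means less inhibition, a higher number more inhibition at the concentration tested (going by the name of the read-out):
- compound 1 `CCn1nc(-c2cccnc2)c2ccccc2c1=O`: 87%
- compound 2 `CCCn1nc(-c2cccnc2)c2ccccc2c1=O`: 86%
- compound 3 `O=c1c2ccccc2c(-c2cccnc2)nn1CC1CCCCC1`: 98%

Compound 1 stands second highest of the three numbers. Compound 2 gives a value within the scatter of it, a number 1 percentage points lower from compound 1 to compound 2 (within the scatter), so no order between these two is claimed. Compound 3 stands apart: a number 11 percentage points higher from compound 1 to compound 3 (beyond the scatter), and likewise a number 12 percentage points higher from compound 2 to compound 3 (beyond the scatter). The three measured steps thus cover only the exchange of hydrogen, methyl and cyclohexyl on the chain attached to the ring nitrogen.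

The unmeasured compound 4 `O=c1c2ccccc2c(-c2cccnc2)nn1CCO` differs from compound 1 as follows: hydroxy in place of hydrogen on a saturated chain carbon, two bonds along the chain from an aromatic nitrogen. Within the data shown here, no measured step introduces a hydroxy group, so none bears directly on this change. The nearest analogy is the step from compound 1 to compound 2, which also alters the chain two bonds from the ring nitrogen and stayed within the scatter. A step of no more than the scatter is therefore expected in this assay, with a slightly lower number held as the more likely side: a number 7 percentage points lower from compound 1 to compound 4 (within the scatter). For compound 4 the estimate in this assay is 80%, with a range from 60% to 95%.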

Compound 4, a percentage reported as inhibition, at one concentration (the size of the read-out at that concentration, not a potency): 69%
For compound 4 the middle estimate is 11 percentage points above the measured one; measured number inside the range.
By their numbers in this assay, from the lowest: compound 4; then compounds 2 and 1 (each within the scatter of the next); then compound 3.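

Hydroxy is the first change at this carbon, on a saturated chain two bonds along the chain from an aromatic nitrogen, to give a step beyond the scatter in this assay: there is a number 18 percentage points lower from compound 1 to compound 4 (beyond the scatter), whereas methyl in place of hydrogen at the same place gave only a number 1 percentage points lower from compound 1 to compound 2 (within the scatter). The comparison with the propyl-bearing compound points the same way, with a number 17 percentage points lower from compound 2 to compound 4 (beyond the scatter) for hydroxy in place of methyl, so at this carbon the outcome depends on which group enters and not merely on the hydrogen being replaced. Hydroxymethyl in place of cyclohexyl gives a number 29 percentage points lower from compound 3 to compound 4 (beyond the scatter), which widens the span seen on this chain and leaves compound 4 as the lowest of the four in this assay.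

No measurement at hand accounts for the lower number with hydroxy. From the compounds shown here alone, it remains open whether methoxy, an amine or a carboxylic acid on the same carbon would lower the number in the same way, and whether a longer chain ending in hydroxy would do so too.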